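This account rests on a few compounds, and the source may have more. Where it says the series, first, only, none or still open, it means among the compounds named here.

Measured compounds in a functional assay (Oryctolagus cuniculus) for inhibition of platelet-activating factor receptor (Cavia porcellus); a lower number here means a stronger inhibitor, a higher number a weaker inhibitor:
Compound 1 `CCC(CC)C(=O)OCC1CN(C(=O)c2cc(OC)c(OC)c(OC)c2)CCN1C(=O)c1cc(OC)c(OC)c(OC)c1` gives 70 nM; 40 nM; 60 nM (3 entries).
Compound 2 `COc1cc(C(=O)N2CCN(C(=O)c3cc(OC)c(OC)c(OC)c3)C(COC(=O)C3CCCCC3)C2)cc(OC)c1OC` gives 290 nM.
Compound 3 `CCCCNC(=O)OCC1CN(C(=O)c2cc(OC)c(OC)c(OC)c2)CCN1C(=O)c1cc(OC)c(OC)c(OC)c1` gives 240 nM.

All three share the same core and differ only in the group attached to the carbonyl of the side chain. Among the measured compounds shown here, compound 3 has the lower of the two single numbers, but the only measured step that reaches it, a 1.2-fold lower number from compound 2 to compound 3 (0.08 log units; within the scatter), is too small to count as a real difference. Compound 1 is recorded as several entries rather than one number, (the several entries of compound 1 in this assay, 70 nM; 40 nM; 60 nM (3 entries)), and all of them sit at lower values than the value of compound 3.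

Compound 4 `CCCC(C)NC(=O)OCC1CN(C(=O)c2cc(OC)c(OC)c(OC)c2)CCN1C(=O)c1cc(OC)c(OC)c(OC)c1` is the next compound in this series. It differs from compound 3 by methyl in place of hydrogen on a saturated chain carbon bound to an amide-type nitrogen and a saturated chain carbon. For the measured compounds named here, the single measured step, from a cyclohexyl group to a butylamino group, is a larger structural swap than this one and still produced no shift beyond the scatter. Going by the values given here, no measured step shows what a methyl added at this position does. The expectation is therefore a step of a 1.1-fold lower number from compound 3 to compound 4 (0.04 log units; within the scatter), that is, no change beyond the usual scatter. Compound 4 is estimated at 220 nM, with a likely range from 80 nM to 600 nM.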

Compound 4, half-maximal inhibitory concentration: 100 nM
Beside the measured number, compound 4's estimate is 2.2-fold (0.34 log units) above it, within the range that was stated.
By their numbers in this assay, from the lowest: compound 4; then compounds 3 and 2 (each within the scatter of the next).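

In this assay, a methyl in place of hydrogen on the saturated chain carbon bound to the amide-type nitrogen gives a shift beyond the scatter: a 2.4-fold lower number from compound 3 to compound 4 (0.38 log units; beyond the scatter). This shows that this carbon responds to a change of a single carbon atom, even though the swap of cyclohexyl for butylamino on the carbonyl carbon had produced no shift beyond the scatter; with the branched group, that same comparison now reads a 2.9-fold lower number from compound 2 to compound 4 (0.46 log units; beyond the scatter). Compound 4 gives 100 nM, a number that still lies above every entry of the compound with the shortest printed record of scatter-free comparison, the side chain of which carries no amino group: the several entries of compound 1 in this assay, 70 nM; 40 nM; 60 nM (3 entries).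

From the compounds shown here alone, whether an ethyl or a longer chain on this same carbon, or a second methyl on it, would lower the number further remains open. Also open, going by these compounds, is why the methyl lowers the number at all, and whether a hydroxyl or an amine at this carbon would be tolerated in its place.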